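The source may report more compounds than this note shows. Statements on the series, on what has been measured and on what is new or still open speak of the compounds shown alone.

In a functional assay on KB cells (Homo sapiens) for inhibition, read by sulforhodamine B assay, with a stated time of 72 h (on this read-out higher numbers stand for weaker inhibition of growth and lower numbers for stronger inhibition of growth), compound 1 (`CN1CCN(C(=O)/C=C/c2ccncc2-c2ccc3ccccc3c2)CC1`) gives > 10000 nM as its result, which is a limit of the assay and not a number. Compound 2 (`CCOC(=O)/C=C/c1ccncc1-c1ccc2c(cnn2C)c1`) gives > 10000 nM as its result, again only a limit. Compound 3 (`O=C(O)/C=C/c1ccncc1-c1ccc2[nH]ccc2c1`) gives > 10000 nM as its result, also only a limit. Compound 2 therefore has no exact number to start from, and the other two results shown are limits as well.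

Compound 4 (`CNC(=O)/C=C/c1ccncc1-c1ccc2c(cnn2C)c1`) keeps the core of compound 2 and carries methylamino in place of ethoxy on a carbonyl carbon, which turns ethoxycarbonyl to methylcarbamoyl. Within the data shown here, no measured pair shows what this swap does, so the limit of > 10000 nM in this assay, at which 3 of the 3 values shown sit, is the only guide. The expected step that the limit leaves unreadable from compound 2 to compound 4 in this assay is estimated to stay within the usual scatter, with no favoured direction. Compound 4 is expected near 12000 nM with an estimated range from 4000 nM to 30000 nM and may well return only a limit too.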

Compound 4, concentration for 50% growth inhibition: > 10000 nM
Compound 4: a limit, no number; the forecaster's own chance of this, stated with the estimate: 85%; the middle value lies beyond the limit too.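

Compound 2 and compound 4 both give only a limit of the assay, not a number, and the step between them cannot be read. The compounds shown leave open how any structural change affects growth inhibition, with every result still unresolved: the limit of > 10000 nM in this assay, at which 4 of the 4 values shown sit.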